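Adding a Methyl to a Long Side Chain

A few compounds are considered here, and "the series" means these few. Any claim that something is new, unique, unknown or untested is made for them only; others in the source may bear on it.

Measured in a functional assay on HCT-116 cells (Homo sapiens) for antiproliferative activity, read by MTT assay, with a stated time of 48 h; a lower number here means a stronger inhibitor, a higher number a weaker inhibitor:
- compound 1 `CCCCC(CCO)n1cnc2c(Cl)nc(Cl)nc21` (15500 nM)
- compound 2 `CCCCCCCCC(CCO)n1cnc2c(Cl)nc(Cl)nc21` (22200 nM)

Compound 2 (22200 nM) lies within the scatter of compound 1 (15500 nM), so the two cannot be ranked. Compound 3 `CCCCCCCCCC(CCO)n1cnc2c(Cl)nc(Cl)nc21` changes compound 2 in one place: methyl in place of hydrogen on a saturated chain carbon, nine bonds along the chain from an aromatic nitrogen. For the measured compounds named here, the only measured step bearing on this is butyl in place of hydrogen on the same chain, a 1.4-fold higher number from compound 1 to compound 2 (0.16 log units; within the scatter) (within the scatter). The smaller methyl change is therefore expected to give no shift beyond the scatter, with an estimated step of a 1.1-fold higher number from compound 2 to compound 3 (0.03 log units; within the scatter) (in this assay). For compound 3 the expected value is 24000 nM (range 13000 nM to 43000 nM).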

Compound 3, half-maximal inhibitory concentration: 32600 nM
Compound 3: the middle estimate sits 1.4-fold (0.13 log units) below what was measured, and the stated range covers the measured number.
By their numbers in this assay, from the lowest: compounds 1, 2 and 3 (each within the scatter of the next, the first and the last beyond it).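

In this assay the added methyl on its own gives a 1.5-fold higher number from compound 2 to compound 3 (0.17 log units; within the scatter) and so cannot be told apart from repeat measurements. Seen across the series, pentyl in place of hydrogen gives a 2.1-fold higher number from compound 1 to compound 3 (0.32 log units; beyond the scatter) and is the first step here to pass the scatter, modestly and toward a weaker inhibitor. Nothing given here explains this shift. Still open, going by these compounds, is whether a longer chain would carry on in the same direction, and what an amine or a carboxylic acid in place of the methyl would do to the number.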